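A trimethoxyphenyl swap on compound 1

The source may hold more compounds than are shown below. What is called first, only, known or untested is meant among the compounds shown, and "the series" means these compounds.

Compound 1 `O=C1/C(=C\c2ccccc2)c2c(ncn2COCc2ccccc2)CCN1Cc1ccccc1`: 20400 nM
Compound 2 `O=C1/C(=C\c2ccccc2)c2c(ncn2COCc2ccccc2)CCN1Cc1ccc(Cl)cc1`: 22200 nM

For the measured compounds named here, in a functional assay on A2780 cells (Homo sapiens) for inhibition, read by MTT assay, with a stated time of 72 h (a higher number here means a weaker inhibitor, a lower number a stronger inhibitor), compound 1 lies within the scatter of compound 2, the only other compound measured, so neither stands apart. Compound 3 `COc1cc(/C=C2\C(=O)N(Cc3ccccc3)CCc3ncn(COCc4ccccc4)c32)cc(OC)c1OC` has no number yet. Its difference from compound 1 is 3,4,5-trimethoxyphenyl in place of phenyl on a double-bonded chain carbon bound to a double-bonded ring carbon. Going by the values given here, the only measured step is a 1.1-fold higher number from compound 1 to compound 2 (0.04 log units; within the scatter), with chloro in place of hydrogen on an aromatic carbon. That step lies at another place in the molecule, so it is a weak guide, and nothing measured yet tests this swap. No step beyond the scatter is therefore expected in this assay, although the uncertainty is wide. The estimated change is a 1.5-fold lower number from compound 1 to compound 3 (0.16 log units; within the scatter). For compound 3 the expected value is 14000 nM, with an estimated range from 3500 nM to 40000 nM.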

Compound 3, half-maximal inhibitory concentration: 8970 nM
Beside the measured number, compound 3's estimate is 1.6-fold (0.19 log units) above it, and the stated range covers the measured number.
By their numbers in this assay, from the lowest: compound 3; then compounds 1 and 2 (each within the scatter of the next).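

In this assay, 3,4,5-trimethoxyphenyl in place of phenyl on a double-bonded chain carbon bound to a double-bonded ring carbon gives a 2.3-fold lower number from compound 1 to compound 3 (0.36 log units; beyond the scatter) and so produces a modest gain in potency. The earlier chloro change gave only a 1.1-fold higher number from compound 1 to compound 2 (0.04 log units; within the scatter) and could not show whether any change to compound 1 would move the number beyond the scatter, whereas this position shows that one can. Nothing in hand explains why this swap lowers the number.

From the compounds shown here alone, the three methoxy groups arrive together, so it remains open whether a single methoxy group would be enough, or how an amine or a carboxylic acid on that aromatic ring would compare. Also open, going by these compounds, is whether the gain would persist if the 3,4,5-trimethoxyphenyl group were joined with the chloro group of compound 2.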